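Halogen swaps on one shared core

The source may report more compounds than this note shows. Statements on the series, on what has been measured and on what is new or still open speak of the compounds shown alone.

Measured compounds:
compound 1 `O=C1NC(=S)/C(=C/c2cccc(Cl)c2)S1`: 17.6%
compound 2 `O=C1NC(=S)/C(=C/c2cccc(F)c2)S1`: 19.8%

In a functional assay on HEp-2 cells (Homo sapiens) for cytotoxicity, read by MTT assay, with a stated time of 72 h, tested at 5 ug/mL (on this read-out lower numbers stand for less inhibition of growth and higher numbers for more inhibition of growth at the one concentration tested), compound 2 gives 19.8%, the higher of the two numbers, with compound 1 nearest at 17.6%; the step of a number 2.2 percentage points higher from compound 1 to compound 2 (within the scatter) is within the scatter. Compound 3 `O=C1NC(=S)/C(=C/c2cccc(Br)c2)S1` carries bromo in place of fluoro on an aromatic carbon, on an aromatic carbon of the six-membered all-carbon ring, meta to a group of 8 heavy atoms. Within the data shown here, the only step bearing on this change is the halogen swap a number 2.2 percentage points higher from compound 1 to compound 2 (within the scatter), which stayed within the scatter. No step beyond the scatter is therefore expected in this assay from compound 2 to compound 3, estimated as a number 1.3 percentage points lower from compound 2 to compound 3 (within the scatter). Compound 3 is expected to give 18.5%, in the range 6% to 32%.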

Compound 3, percent growth inhibition at one concentration: -1.04%
Compound 3: the middle estimate sits 19.5 percentage points above what was measured, and the stated range ends above it.
By their numbers in this assay, from the lowest: compound 3; then compounds 1 and 2 (each within the scatter of the next).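

In this assay the halogen at this position is not interchangeable: bromo in place of fluoro gives a number 20.8 percentage points lower from compound 2 to compound 3 (beyond the scatter) and bromo in place of chloro gives a number 18.6 percentage points lower from compound 1 to compound 3 (beyond the scatter) while fluoro and chloro stayed within the scatter of each other. On an aromatic carbon of this ring, bromo alone therefore separates from the other two halogens. Nothing available here accounts for this drop. Open, on these data alone, is whether the loss belongs to bromo alone or extends to larger groups at this place, such as methoxy or trifluoromethyl, and whether it holds at other concentrations.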